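A few compounds are considered here, and "the series" means these few. Any claim that something is new, unique, unknown or untested is made for them only; others in the source may bear on it.

Measured in a functional assay on DU-145 cells (Homo sapiens) for inhibition, read by trypan blue exclusion, with a stated time of 96 h; on this read-out higher numbers stand for weaker inhibition of growth and lower numbers for stronger inhibition of growth:
compound 1, `O=C(/C(=C\c1ccc([N+](=O)[O-])c(O)c1)SCc1ccc(Br)cc1)c1cc(Cl)ccc1O`, 10000 nM
compound 2, `COc1ccccc1/C=C(/SCc1ccc(C)cc1)C(=O)c1ccc(Cl)cc1`, 10000 nM
compound 3, `O=C(/C(=C\c1ccc(O)c([N+](=O)[O-])c1)Sc1c(F)c(F)c(F)c(F)c1F)c1ccc(Br)cc1`, 10000 nM

On these numbers compound 1 stands level with compound 2 and with compound 3: the three readings agree at the digits shown, and the gaps among them lie within the usual scatter, so no order can be read among them. Compound 4, `O=C(O)c1ccc(C(=O)/C(=C\c2ccc([N+](=O)[O-])c(O)c2)SCc2ccc(Br)cc2)cc1`, has not yet been measured in this assay. It differs from compound 1 in one place: 4-carboxyphenyl in place of 5-chloro-2-hydroxyphenyl on a carbonyl carbon. For the measured compounds named here, no measured pair in this set differs in a single place, so there is no earlier step of this kind to draw on. Compound 1 and its two companions give the same reading, and the step is expected to be no change at the digits printed from compound 1 to compound 4 (within the scatter), none beyond the scatter. Compound 4 is therefore expected to give about 10000 nM, most likely within 5000 nM to 20000 nM.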

Compound 4, concentration for 50% growth inhibition: 10000 nM
Estimate against measurement, compound 4: no gap at the digits printed; the range from low to high includes it.
By their numbers in this assay, from the lowest: compounds 1, 2, 3 and 4 (each within the scatter of the next).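

In this assay the reading shows no change at the digits printed from compound 1 to compound 4 (within the scatter) when 4-carboxyphenyl replaces 5-chloro-2-hydroxyphenyl on a carbonyl carbon. For the compounds shown here, this is the first comparison in the set that changes a single place, and it shows that this exchange of one substituted phenyl group for another leaves the growth-inhibition reading where it was. Nothing measured here explains this result.

Going by these compounds, whether any group at this carbonyl carbon can move the reading remains open. An amine or a longer chain in place of the ring would test this.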